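Bromo substitution on the fused ring across two cores

The source may report more compounds than this note shows. Statements on the series, on what has been measured and on what is new or still open speak of the compounds shown alone.

Compound 1 `COc1ccc(C2=NN(C3=NC(=O)/C(=C4\C(=O)Nc5ccccc54)S3)C(c3ccc(OC)cc3)C2)cc1` and compound 2 `COc1ccc(C2=NN(C3=NC(=O)/C(=C4\C(=O)Nc5ccc(Br)cc54)S3)C(c3ccc(OC)cc3)C2)cc1` share a core and differ only by bromo in place of hydrogen on an aromatic carbon. In a functional assay on cells (Cancer cell lines, Homo sapiens) for cytotoxicity, read by sulforhodamine B assay, with a stated time of 48 h (a higher number here means a weaker inhibitor of growth, a lower number a stronger inhibitor of growth), compound 1 gives 43900 nM, and compound 2 gives 200 nM, so the change gives a 220-fold lower number from compound 1 to compound 2 (2.34 log units; beyond the scatter). Compound 3 `CN(C)c1ccc(C2CC(c3ccccc3)=NN2C2=NC(=O)/C(=C3\C(=O)Nc4ccccc43)S2)cc1` carries a different core; how it differs from compound 1 is not broken down here. In this assay compound 3 gives 1110 nM, a lower number than compound 1 and a higher number than compound 2. Compound 4 `CN(C)c1ccc(C2CC(c3ccccc3)=NN2C2=NC(=O)/C(=C3\C(=O)Nc4ccc(Br)cc43)S2)cc1` is the analogue of compound 3 with bromo in place of hydrogen on an aromatic carbon; the place lines of this change and of the change from compound 1 to compound 2 read the same, so it is the same change made on another core. For the measured compounds named here, its size on the second core has been seen once only, and that single observation is very large, so a step of similar direction but smaller size is expected for compound 4, a 22-fold lower number from compound 3 to compound 4 (1.35 log units; beyond the scatter), because the one measured step is a 220-fold lower number from compound 1 to compound 2 (2.34 log units; beyond the scatter). Compound 4 is therefore estimated at 50 nM, with a range from 8 nM to 400 nM.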

Compound 4, concentration for 50% growth inhibition: 210 nM
The estimate for compound 4 lay 4.2-fold (0.62 log units) below the measured number; low and high end bracket the measured number.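

Bromo in place of hydrogen on an aromatic carbon again gives a lower number on the second core, with a 5.3-fold lower number from compound 3 to compound 4 (0.72 log units; beyond the scatter) in this assay and the same direction as on the core of compound 1. The direction therefore carries over in these two pairs, but the size of the step does not: the same change on two cores in this assay, a 220-fold lower number (2.34 log units; beyond the scatter) from compound 1 to compound 2 and a 5.3-fold lower number (0.72 log units; beyond the scatter) from compound 3 to compound 4, 42-fold (1.62 log units) apart, beyond the scatter of two such steps. This shows that the size measured on one core is a poor guide to the size on the other, but it does not show which structural difference between the two cores goes with the smaller step, and two pairs establish no rule for the series.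

The compounds shown leave open whether chloro or fluoro on the same aromatic carbon would give steps like those of bromo, and how an amine or a carboxylic acid would behave there. They also leave open the size of the bromo step on a core that keeps one methoxy group and carries an unsubstituted phenyl ring in place of the other methoxy-bearing ring.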